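The compounds below may be only part of what the source reports. "The series", "measured", "known", "first", "only" and "open" are said of these compounds alone.

- Compound 1 `C=C1[C@H](OC(C)=O)C[C@H](OC(C)=O)[C@@]2(C)[C@@H](OC(=O)CC(C)C)C[C@@H](OC(C)=O)[C@]3(CO3)[C@@H]2[C@H](OC(C)=O)[C@]2(O)[C@@H](C)C(=O)O[C@H]2[C@H]1Cl`: 15100 nM
- Compound 2 `C=C1[C@H](OC(=O)CC(C)C)C[C@H](OC(C)=O)[C@@]2(C)[C@@H](OC(C)=O)[C@@H](OC(=O)CC(C)C)[C@@H](OC(C)=O)[C@]3(CO3)[C@@H]2[C@H](OC(C)=O)[C@]2(O)[C@@H](C)C(=O)O[C@H]2[C@H]1Cl`: 17400 nM
- Compound 3 `C=C1[C@H]2O[C@]3([C@@H](C)C(=O)O[C@H]3[C@H]1Cl)[C@@H](OC(C)=O)[C@H]1[C@@]3(CO3)[C@H](OC(=O)CC(C)C)C[C@H](OC(C)=O)[C@]1(C)[C@@H](OC(C)=O)[C@H]2OC(C)=O`: < 300 nM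

All three compounds were tested in a functional assay on MG-63 cells (Homo sapiens) for cytotoxicity, read by MTT assay; on this read-out lower numbers stand for stronger inhibition and higher numbers for weaker inhibition. Compound 3 is reported only as a limit, < 300 nM, and not as a number. This limit lies far under the values of compound 1 and compound 2.

Compound 4 `C=C1[C@H]2O[C@]3([C@@H](C)C(=O)O[C@H]3[C@H]1Cl)[C@@H](OC(C)=O)[C@H]1[C@@]3(CO3)[C@H](OC(C)=O)C[C@H](OC(C)=O)[C@]1(C)[C@@H](OC(C)=O)[C@H]2OC(C)=O` differs from compound 3 in one ester: hydrogen in place of isopropyl on a saturated chain carbon bound to a carbonyl carbon. In words, hydrogen replaces isopropyl on a saturated chain carbon bound to a carbonyl carbon, turning isobutylcarbonyl into acetyl. For the measured compounds named here, no measured pair shows this change alone, so only a modest step toward weaker inhibition is expected in this assay. The expected step is an at least 1.3-fold higher number from compound 3 to compound 4 (0.12 log units; that floor lies within the scatter). Compound 4 is estimated at 400 nM, with an expected range of 100 nM to 2500 nM.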

Compound 4, half-maximal inhibitory concentration: > 45700 nM
Compound 4: only a limit was reported (the forecaster's own chance of this, stated with the estimate: 40%); at least 110-fold (2.05 log units) between middle value and limit.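

In this assay, this single ester change, with hydrogen replacing isopropyl and isobutylcarbonyl becoming acetyl, gives an at least 150-fold higher number from compound 3 to compound 4 (2.18 log units; beyond the scatter), the first view of this position on its own. Compound 3 is reported only as a limit: the limit of < 300 nM in this assay, at which 1 of the 4 values shown sits. Compound 4 is likewise reported only as a limit, so the true size of the step remains unknown: the limit of > 45700 nM in this assay, at which 1 of the 4 values shown sits.

On these data alone, whether a propionyl or butyryl ester at this place would keep the stronger inhibition of compound 3 remains open. So does the effect of a longer chain or a free hydroxyl group here.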